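Urea phenol series: trifluoromethyl for chloro on the aryl urea

The source may report more compounds than this note shows. Statements on the series, on what has been measured and on what is new or still open speak of the compounds shown alone.

Measured so far in a functional assay on U-251 cells (Homo sapiens) for inhibition, read by sulforhodamine B assay, with a stated time of 48 h; on this read-out higher numbers stand for lower toxicity in this test and lower numbers for higher toxicity in this test:
- compound 1 `COc1cc(-c2nn(-c3cccc(NC(=O)Nc4cc(C(F)(F)F)cc(C(F)(F)F)c4)c3)cc2-c2ccncc2)ccc1Cl`, 3180 nM
- compound 2 `COc1cc(-c2nn(-c3cccc(NC(=O)Nc4ccc(Cl)c(Cl)c4)c3)cc2-c2ccncc2)ccc1Cl`; for compound 2 the assay gives only the limit > 50000 nM
- compound 3 `O=C(Nc1cccc(-n2cc(-c3ccncc3)c(-c3ccc(Cl)c(O)c3)n2)c1)Nc1ccc(Cl)c(Cl)c1`; for compound 3 the assay gives only the limit > 32500 nM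

Compound 3 stands at a limit, not a number; compound 2 stands at a limit as well. For the measured compounds named here, the one measured step that reaches compound 3, a step that the two limits leave unreadable from compound 2 to compound 3, is therefore unreadable, as the two limits the limit of > 32500 nM in this assay, at which 1 of the 3 values shown sits, and the limit of > 50000 nM in this assay, at which 1 of the 3 values shown sits, do not fix a size. Going by the values given here, compound 1 is the only compound with a number, and it differs from compound 2 in more than one place, so its value and the limit of compound 2 show only that compound 1 gives a number where compound 2 does not.

Compound 4 `O=C(Nc1cccc(-n2cc(-c3ccncc3)c(-c3ccc(Cl)c(O)c3)n2)c1)Nc1ccc(Cl)c(C(F)(F)F)c1` is compound 3 with trifluoromethyl in place of chloro on an aromatic carbon. Among the compounds with values here, no measured step in this assay follows that change alone, so nothing in the measured steps sets its size or direction. Compound 1 carries trifluoromethyl groups on the same ring and gives a number, which is the only pointer available. For compound 4 the expected value in this assay is 15000 nM, with a range from 4000 nM to 50000 nM, a step of an at least 2.1-fold lower number from compound 3 to compound 4 (0.33 log units; beyond the scatter) that may well again end at a limit.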

Compound 4, concentration lethal to 50% of the cells: 2740 nM
The estimate for compound 4 lay 5.5-fold (0.74 log units) above the measured number, and the stated range ends above it.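

In this assay, the change from 3,4-dichlorophenyl to 4-chloro-3-(trifluoromethyl)phenyl on the urea gives the only readable step among the compounds shown: an at least 11-fold lower number from compound 3 to compound 4 (1.07 log units; beyond the scatter). For the compounds shown here, a single replacement of chloro by trifluoromethyl at this aromatic carbon is therefore enough to turn a limit into a number in the phenol series, which no earlier step isolated. The step sets only a minimum size, as compound 3 stands at a limit: the limit of > 32500 nM in this assay, at which 1 of the 4 values shown sits.

On these data alone, whether the same replacement gives a step of similar size in the methyl ether, compound 2, stays open, and the step from compound 2 to compound 3 cannot be read. Also open, as far as these compounds go, is whether a nitrile, a bromo group or a methyl group on this carbon would give a number like that of trifluoromethyl.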